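The source may report more compounds than this note shows. Statements on the series, on what has been measured and on what is new or still open speak of the compounds shown alone.

Measured so far:

Compound 1, `Cc1cc(-n2cc(C(=O)Nc3cc(F)cc(F)c3)c(=O)c3ccc(N(C)C)nc32)ccc1OCCCCCCC[N+]12CCN(CC1)CC2`, in an assay on LX2 cells for inhibition of COL1A1 promoter (Homo sapiens), read by a luciferase reporter, with a stated time of 24 h, tested at 50 uM (a higher number here means a stronger effect of the compound at the concentration tested, a lower number a weaker effect), compound 1 gives 20.8%.
Compound 2, `CN(C)c1ccc2c(=O)c(C(=O)Nc3cc(F)cc(F)c3)cn(-c3ccc(OCCCCCCC[N+]45CCN(CC4)CC5)c(Cl)c3)c2n1`, in this assay compound 2 gives 20.5%.
Compound 3, `Cc1ccc(-n2cc(C(=O)Nc3cc(F)cc(F)c3)c(=O)c3ccc(N(C)C)nc32)cc1OCCCCCCC[N+]1(C)CCN(C)CC1`, in this assay compound 3 gives 25%.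

The three values sit close together, and none of the gaps between them is said to exceed the scatter of the measurement. Compound 1 and compound 2 share one core and differ only by chloro in place of methyl on an aromatic carbon, a change that produced a number 0.3 percentage points lower from compound 1 to compound 2 (within the scatter). The difference between the core of compound 1 and the core of compound 3 is not broken down here.

Compound 4, `CN1CC[N+](C)(CCCCCCCOc2cc(-n3cc(C(=O)Nc4cc(F)cc(F)c4)c(=O)c4ccc(N(C)C)nc43)ccc2Cl)CC1`, has not yet been measured. It is made from compound 3 by chloro in place of methyl on an aromatic carbon. Among the compounds with values here, this is the same kind of change as the one from compound 1 to compound 2, though the surroundings differ: in compound 2 the chloro stands ortho to a large group and meta to a large group, in compound 4 ortho to a large group and para to a large group. Because that earlier change gave a number 0.3 percentage points lower from compound 1 to compound 2 (within the scatter), the step is expected to be a number 1 percentage points lower from compound 3 to compound 4 (within the scatter). For compound 4 the estimate is 24%, with a likely range from 12% to 36%.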

Compound 4, a percentage reported as inhibition, at one concentration (the size of the read-out at that concentration, not a potency): 45.2%
Compound 4: middle estimate off by 21.2 percentage points, on the low side; measured number above the stated range.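

In this assay, chloro in place of methyl on an aromatic carbon gave a number 20.2 percentage points higher from compound 3 to compound 4 (beyond the scatter). Set beside the earlier step, the same change did not carry over from one core to the other with the same size: the same change on two cores in this assay, a number 0.3 percentage points lower (within the scatter) from compound 1 to compound 2 and a number 20.2 percentage points higher (beyond the scatter) from compound 3 to compound 4, 20.5 percentage points apart, beyond the scatter of two such steps. This shows that, in this series, a step read on one core cannot simply be transferred to another, but two steps do not show that the core is what matters, as the chloro also has different surroundings in the two pairs, and they say nothing about how the change would behave on any further core.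

On these data alone, it remains open whether the rise on the core of compound 3 belongs to chloro alone or would also appear with another group in that place, such as fluoro, bromo or trifluoromethyl. As far as these compounds go, it is equally open whether the step would keep its size with a longer chain on the ring oxygen.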